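Moving the nitro substituent around the aryl amine

The compounds below may be only part of what the source reports. "The series", "measured", "known", "first", "only" and "open" are said of these compounds alone.

Within the data shown here, compound 2 `CCOC(=O)C1=C(Nc2ccc([N+](=O)[O-])cc2)S/C(=C\c2ccc[nH]2)C1=O` gives 15600 nM in a functional assay on JAR cells (Homo sapiens) for inhibition, read by MTT assay, with a stated time of 72 h (on this read-out lower numbers stand for stronger inhibition and higher numbers for weaker inhibition), the upper of the two numbers measured so far. Compound 1 `CCOC(=O)C1=C(Nc2ccccc2Br)S/C(=C\c2ccc[nH]2)C1=O` gives 8900 nM in this assay, and the step of a 1.8-fold higher number from compound 1 to compound 2 (0.24 log units; within the scatter) lies within the scatter. Compound 3 `CCOC(=O)C1=C(Nc2cccc([N+](=O)[O-])c2)S/C(=C\c2ccc[nH]2)C1=O` differs from compound 2 by 3-nitrophenyl in place of 4-nitrophenyl on an amine nitrogen. Among the measured compounds shown here, the only measured step that bears on this change is the one from compound 1 to compound 2, which also varied the aryl group on the amine nitrogen and stayed within the scatter, so no movement beyond the scatter is expected in this assay; the estimated step is a 1.2-fold lower number from compound 2 to compound 3 (0.08 log units; within the scatter). Compound 3 is expected to give 13000 nM, within 5000 nM to 35000 nM.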

Compound 3, half-maximal inhibitory concentration: 10100 nM
Estimate against measurement, compound 3: 1.3-fold (0.11 log units) above, within the range that was stated.
By their numbers in this assay, from the lowest: compounds 1, 3 and 2 (each within the scatter of the next).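

The 3-nitrophenyl and 4-nitrophenyl groups on the amine nitrogen give a 1.5-fold lower number from compound 2 to compound 3 (0.19 log units; within the scatter) in this assay, so moving the nitro group between these two places produces no readable difference. With 3-nitrophenyl in place of 2-bromophenyl, the step is a 1.1-fold higher number from compound 1 to compound 3 (0.05 log units; within the scatter), and all three aryl groups now lie within the scatter of one another. No evidence is available to explain this flat response.

Still open, on these data alone, is whether a carboxylic acid or an amine on this aryl ring, or a longer alkyl chain in its place, would move the number beyond the scatter.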